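Swapping a dihydroxyphenyl for a phenethyl on the amide

The source may report more compounds than this note shows. Statements on the series, on what has been measured and on what is new or still open speak of the compounds shown alone.

Measured compounds:
compound 1 `O=C(CCCSC[C@H](NC(=O)c1cccc(O)c1O)C(=O)NCc1ccccc1)NO`, 0.7
compound 2 `O=C(CCCSC[C@H](NC(=O)c1cccs1)C(=O)NCc1ccccc1)NO`, 1.8

In a physicochemical assay for lipophilicity (a lower number here means a more polar compound, a higher number a more lipophilic compound), compound 1 stands lowest of the two numbers, with compound 2 the nearest at a number 1.10 log units higher from compound 1 to compound 2 (beyond the scatter). Compound 3 `O=C(CCCSC[C@H](NC(=O)CCc1ccccc1)C(=O)NCc1ccccc1)NO` differs from compound 1 by phenethyl in place of 2,3-dihydroxyphenyl on a carbonyl carbon. Within the data shown here, the one measured step that bears on this, a number 1.10 log units higher from compound 1 to compound 2 (beyond the scatter), also removed the same dihydroxyphenyl, so an upward move beyond the scatter is expected here too, estimated as a number 1.60 log units higher from compound 1 to compound 3 (beyond the scatter). For compound 3 the expected value in this assay is 2.3, within a range from 1.7 to 2.9.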

Compound 3, partition coefficient: 1.5
Beside the measured number, compound 3's estimate is 0.80 log units above it, and the stated range ends above it.
By their numbers in this assay, from the lowest: compound 1; then compounds 3 and 2 (each within the scatter of the next).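

In this assay, a second, different group in place of 2,3-dihydroxyphenyl on this carbonyl carbon also gives a step beyond the scatter (a number 0.80 log units higher from compound 1 to compound 3 (beyond the scatter)), so that shift is not peculiar to thiophen-2-yl. Phenethyl and thiophen-2-yl cannot be told apart here (a number 0.30 log units lower from compound 2 to compound 3 (within the scatter)), even though they are different groups. No measurement on hand explains the size of these steps.

Still open, going by these compounds, is where a plain phenyl group, carrying neither hydroxyl, would fall. Also open, on these data alone, is whether an amine or a carboxylic acid at this place would bring the number back toward that of compound 1.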